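Benzothiophenyl in place of chlorophenyl: series notes

The source may report more compounds than this note shows. Statements on the series, on what has been measured and on what is new or still open speak of the compounds shown alone.

Measured so far:
compound 1 `S=C(NCc1cccnc1)SCCc1nnc(-c2ccc(Cl)cc2)o1`: 860 nM
compound 2 `S=C(NCc1cccnc1)SCCc1nnc(-c2ccc3ccccc3n2)o1`: 790 nM

In a functional assay on SK-BR-3 cells (Homo sapiens) for cytotoxicity, read by resazurin assay, with a stated time of 72 h (on this read-out lower numbers stand for stronger inhibition and higher numbers for weaker inhibition), compound 1 gives 860 nM and compound 2 gives 790 nM; the two values lie within the scatter of each other, so compound 1 cannot be set apart from compound 2 on these numbers. Among the compounds with values here, no step between measured compounds is available. Compound 3 `S=C(NCc1cccnc1)SCCc1nnc(-c2cc3ccccc3s2)o1` differs from compound 1 by 1-benzothiophen-2-yl in place of 4-chlorophenyl on an aromatic carbon. Within the data shown here, the one comparison at hand, compound 1 against compound 2, shows that exchanging the group at this position left the number within the scatter. The expected step is therefore a 1.2-fold lower number from compound 1 to compound 3 (0.09 log units; within the scatter), not beyond the scatter. Compound 3 is estimated at 700 nM, range 300 nM to 1800 nM.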

Compound 3, half-maximal inhibitory concentration: 5320 nM
The estimate for compound 3 lay 7.6-fold (0.88 log units) below the measured number; measured number outside the range, above it.
By their numbers in this assay, from the lowest: compounds 2 and 1 (each within the scatter of the next); then compound 3.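

In this assay this position proves sensitive to the group it carries: 1-benzothiophen-2-yl in place of 4-chlorophenyl gives a 6.2-fold higher number from compound 1 to compound 3 (0.79 log units; beyond the scatter) while the earlier pair stayed within the scatter. An exchange of one aromatic group for another at this carbon is therefore not neutral in general. Nothing available explains the step.

Going by these compounds, how a plain phenyl, a benzofuranyl or an aromatic group carrying an amine would read at this position stays open. So does whether the step belongs to the sulfur-containing ring or to the loss of chlorine.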